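A few compounds are considered here, and "the series" means these few. Any claim that something is new, unique, unknown or untested is made for them only; others in the source may bear on it.

Of the compounds shown here, three built on a shared core have been measured in an ADME assay on cells (Hepatocyte, Rattus norvegicus) for metabolic stability; a lower number here means slower removal, a higher number faster removal of the compound. Compound 1 `CNC(=O)CN1CCC(c2cc3c(-c4ccc(=O)n(C(C)C)c4)ccnc3[nH]2)CC1` gives 8.9 uL/min. Compound 2 `COc1cc(F)ccc1-c1ccnc2[nH]c(C3CCN(CC(=O)N(C)C)CC3)cc12` gives 38 uL/min. Compound 3 `CC(C)n1cc(-c2ccnc3[nH]c(C4CCN(CC(=O)N(C)C)CC4)cc23)ccc1=O` gives 2.3 uL/min and stands lowest of the three: the step of a 3.9-fold lower number from compound 1 to compound 3 (0.59 log units; beyond the scatter) is modest, and the step of a 17-fold lower number from compound 2 to compound 3 (1.22 log units; beyond the scatter) is large. Compound 4 `CN(C)C(=O)CN1CCC(c2cc3c(-c4ccc(=O)n(C5CCC5)c4)ccnc3[nH]2)CC1` has not yet been measured. It differs from compound 3 in one place: cyclobutyl in place of isopropyl on an aromatic nitrogen. Neither measured step bears directly on this change. The step from compound 1 to compound 3 concerns the amide-type nitrogen, and the step from compound 2 to compound 3 concerns the aromatic carbon, while the isopropyl on the aromatic nitrogen is common to compound 1 and compound 3. Within the data shown here, no measured step therefore speaks to the exchange of isopropyl for cyclobutyl, and the expectation rests on compound 3 alone. Compound 4 is expected to lie close to compound 3, with an expected step of a 1.3-fold higher number from compound 3 to compound 4 (0.12 log units; within the scatter), not beyond the scatter. The estimate for compound 4 is 3 uL/min, expected to fall between 1.2 uL/min and 7.5 uL/min.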

Compound 4, intrinsic clearance in a liver preparation (reported as CLH), per the amount of preparation that the assay uses: 5.8 uL/min
Compound 4: the middle estimate sits 1.9-fold (0.29 log units) below what was measured; the range from low to high includes it.
By their numbers in this assay, from the lowest: compound 3; then compounds 4 and 1 (each within the scatter of the next); then compound 2.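

Among these compounds, the exchange of isopropyl for cyclobutyl on the aromatic nitrogen gives a 2.5-fold higher number from compound 3 to compound 4 (0.40 log units; beyond the scatter) in this assay, the first reading of any change at this position, and it shows that the number responds to the group carried there even though this step is only modest. The change is confined to the carbon group: one group of carbon atoms without a ring gives way to a four-membered non-aromatic ring of carbon only, and neither group has hydrogen-bond donors or acceptors or a net charge. No measurement at hand accounts for the direction or size of this step.

The compounds shown do not separate the effect of the added carbon from that of closing the ring, a question that cyclopropyl, tert-butyl or a longer chain such as n-butyl on the same nitrogen could address. They also leave open whether the step would keep its direction and size with the methyl amide of compound 1 in place of the dimethyl amide shared by compound 3 and compound 4.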